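The source may report more compounds than this note shows. Statements on the series, on what has been measured and on what is new or still open speak of the compounds shown alone.

Series notes. Compound 1 `O=[N+]([O-])c1ccccc1CNc1cc(Br)cc2[nH]ncc12` gives 52% in an assay for inhibition of Tryptophan 2,3-dioxygenase (Homo sapiens), with stated times of 10 min and 60 min, tested at 10 uM (a higher number here means a stronger effect of the compound at the concentration tested, a lower number a weaker effect), and stands lowest of the three numbers in hand. Nearest to compound 1 is compound 3 `FC(F)(F)c1cc(NC[C@@H]2CCCCN2)c2cn[nH]c2c1`, which in this assay gives 64%; furthest is compound 2 `O=[N+]([O-])c1ccc(O)cc1CNc1cc(Br)cc2[nH]ncc12`, which in this assay gives 96%. Going by the values given here, the only measured step between compounds that differ in one place, a number 44 percentage points higher from compound 1 to compound 2 (beyond the scatter), concerns a different aromatic carbon and does not bear on the change considered here.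

Compound 4 `O=[N+]([O-])c1ccccc1CNc1cccc2[nH]ncc12` differs from compound 1 as follows: hydrogen in place of bromo on an aromatic carbon. Among the compounds with values here, no measured pair varies this place, so no step is available to scale an expectation from; compound 1 carries bromo there and compound 3 carries trifluoromethyl, while no measured compound carries hydrogen at that place. On that basis compound 4 is expected to lie lower than compound 1 in this assay, though with wide uncertainty. The expected step is a number 24 percentage points lower from compound 1 to compound 4 (beyond the scatter) in this assay. For compound 4 the estimate in this assay is 28%, with a range from 5% to 55%.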

Compound 4, a percentage reported as inhibition, at one concentration (the size of the read-out at that concentration, not a potency): 45%
Beside the measured number, compound 4's estimate is 17 percentage points below it, within the range that was stated.
By their numbers in this assay, from the lowest: compounds 4 and 1 (each within the scatter of the next); then compound 3; then compound 2.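

Going by these compounds alone, the only measured step at this place is a number 7 percentage points lower from compound 1 to compound 4 (within the scatter) in this assay, so on the shared core of compound 1 the read-out at the tested concentration does not depend measurably on bromo being present. Within the data shown here, the step of a number 44 percentage points higher from compound 1 to compound 2 (beyond the scatter) therefore remains the only single-place step beyond the scatter, and it concerns a different aromatic carbon. No available evidence bears on this result.

On these data alone, it remains open whether hydrogen and bromo would also stay within the scatter of each other with the hydroxy group of compound 2 in place. As far as these compounds go, it is also open whether a carboxylic acid, an amine or a methoxy group at this aromatic carbon would move the read-out in this assay beyond the scatter.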